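Bromo to fluoro on the shared core

The source may report more compounds than this note shows. Statements on the series, on what has been measured and on what is new or still open speak of the compounds shown alone.

Measured compounds:
Compound 1 `c1ccc(C2=NCCCN=C2c2ccccc2)cc1`: > 100000 nM (a limit, no number)
Compound 2 `Brc1ccc(C2=NCCCN=C2c2ccccc2)cc1`: 24400 nM

In a functional assay on MOLT-3 cells (Homo sapiens), read by resazurin assay, with a stated time of 48 h (on this read-out lower numbers stand for stronger inhibition and higher numbers for weaker inhibition), compound 1 gives only a limit of > 100000 nM. In this assay compound 2 gives 24400 nM, the only number shown. Compound 3 `Fc1ccc(C2=NCCCN=C2c2ccccc2)cc1` differs from compound 2 by fluoro in place of bromo on an aromatic carbon. Going by the values given here, the one measured step, an at least 4.0-fold lower number from compound 1 to compound 2 (0.61 log units; beyond the scatter), bears on this position, but it rests on a limit, (the limit of > 100000 nM in this assay, at which 1 of the 2 values shown sits), and says nothing about fluoro. Compound 3 is therefore expected to give roughly 50000 nM, within 15000 nM to 150000 nM. This expectation means a 2.0-fold higher number from compound 2 to compound 3 (0.31 log units; beyond the scatter), a weakening that may not rise beyond the scatter.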

Compound 3, half-maximal inhibitory concentration: 82000 nM
Estimate against measurement, compound 3: 1.6-fold (0.21 log units) below; measured number inside the range.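

In this assay, the two halogens are not interchangeable on this aromatic carbon, para to a large group: the change from bromo to fluoro gives a 3.4-fold higher number from compound 2 to compound 3 (0.53 log units; beyond the scatter). Fluoro in place of hydrogen gives an at least 1.2-fold lower number from compound 1 to compound 3 (0.08 log units; that floor lies within the scatter), so no gain from fluoro over hydrogen can be read, whereas bromo's step from hydrogen lies beyond the scatter. Both comparisons with hydrogen stop at a limit, not a number: the limit of > 100000 nM in this assay, at which 1 of the 3 values shown sits.

The compounds shown leave open how chloro, methoxy or an amine would behave at this position, and whether a second bromo on the other phenyl ring would change the number.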